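Phenyl for methyl on a sulfur

The source may report more compounds than this note shows. Statements on the series, on what has been measured and on what is new or still open speak of the compounds shown alone.

Measured so far in a functional assay on HeLa cells (Homo sapiens) for antiproliferative activity, read by resazurin assay; a higher number here means a weaker inhibitor, a lower number a stronger inhibitor:
- Compound 1 `CSC(=S)SCC(=O)c1ccc(Cl)c(Cl)c1` gives 6310 nM
- Compound 2 `CCSC(=S)SCC(=O)c1ccc(C)cc1` gives 3980 nM

Repeated measurements of this kind always vary a little, and the gap between these two values lies within that usual scatter. Going by the values given here, compound 1 therefore stands level with compound 2, the only other compound measured, and neither can be ranked above the other.

The next compound to be tested is compound 3 `O=C(CSC(=S)Sc1ccccc1)c1ccc(Cl)c(Cl)c1`, which keeps the rest of compound 1 and changes one group. The difference is phenyl in place of methyl on a sulfur. Among the compounds with values here, no pair of measured compounds differs in this one place alone, so the data do not show what this swap does. Within the data shown here, the only guides are the levels of compound 1 (6310 nM) and compound 2 (3980 nM), and the expectation is correspondingly loose.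

The expected step of a 1.6-fold lower number from compound 1 to compound 3 (0.20 log units; within the scatter) is small, towards a lower number in this assay, and may well stay within the scatter. For compound 3 the estimate is 4000 nM (expected range 1300 nM to 12000 nM).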

Compound 3, half-maximal inhibitory concentration: 20000 nM
Beside the measured number, compound 3's estimate is 5.0-fold (0.70 log units) below it; measured number above the stated range.
By their numbers in this assay, from the lowest: compounds 2 and 1 (each within the scatter of the next); then compound 3.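

Placing phenyl in place of methyl on a sulfur, in this assay, gives a 3.2-fold higher number from compound 1 to compound 3 (0.50 log units; beyond the scatter). Going by these compounds alone, this is the first step that can be read as a real change, and it shows that this position is not indifferent to what it carries: with the rest of compound 1 held fixed, the swap to phenyl yields a weaker inhibitor, although the step is modest. Nothing available says why the swap has this effect.

Still open, as far as these compounds go, is whether the weakening follows from the aromatic ring itself or would come with any group holding more atoms than methyl, which a longer chain such as butyl, or a cyclohexyl ring, on this sulfur could help to separate. Also open, from the compounds shown here alone, is whether phenyl would have the same effect on the rest of compound 2, and whether a phenyl ring carrying an amine or a carboxylic acid would behave like the plain phenyl of compound 3.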